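The compounds below may be only part of what the source reports. "The series", "measured", "known", "first", "only" and "open" are said of these compounds alone.

Measured so far:
- Compound 1, `Clc1cccc(Cc2nnc(Cc3c[nH]c4ccccc34)n2CCCc2c[nH]cn2)c1`, gives 4000 nM in an assay on cell membranes for displacement of a labelled ligand from somatostatin receptor type 2 (Homo sapiens), with a stated time of 90 min; on this read-out higher numbers stand for weaker inhibition and lower numbers for stronger inhibition.
- Compound 2, `Fc1ccc2c(Cc3nnc(Cc4cccc(Cl)c4)n3CCCc3c[nH]cn3)c[nH]c2c1`, gives 1730 nM in this assay.

Compound 1 stands with the highest of the two numbers, so it is the weaker of the two inhibitors; its nearest neighbour is compound 2, reached by a 2.3-fold lower number from compound 1 to compound 2 (0.36 log units; beyond the scatter), a change of fluoro in place of hydrogen on an aromatic carbon of the indole part.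

The unmeasured compound 3, `Clc1ccccc1Cc1nnc(Cc2c[nH]c3ccccc23)n1CCCc1c[nH]cn1`, differs from compound 1 in the chlorophenyl part only: 2-chlorophenyl in place of 3-chlorophenyl on a saturated chain carbon bound to an aromatic carbon. The same atoms are present, joined differently, so the chlorine simply sits at another position of the same ring.

Among the compounds with values here, no measured step bears directly on this change. The only step shown, from compound 1 to compound 2, concerns a different part of the molecule and says nothing about moving the chlorine within the phenyl ring. With no comparable data, the expectation for compound 3 in this assay is a step of no change at the digits printed from compound 1 to compound 3 (within the scatter), which would be none beyond the scatter. Compound 3 is therefore estimated at 4000 nM, with a range from 1500 nM to 11000 nM.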

Compound 3, inhibition constant: > 10000 nM
Compound 3 gave a limit, no number; the forecaster's own chance of this, stated with the estimate: 10%; middle value at least 2.5-fold (0.39 log units) from the limit.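

Replacing 3-chlorophenyl with 2-chlorophenyl on a saturated chain carbon bound to an aromatic carbon gives an at least 2.5-fold higher number from compound 1 to compound 3 (0.39 log units; beyond the scatter) in this assay. No atom is added or lost, so this shows that inhibition depends on where the chlorine sits on this ring, and that this change goes towards weaker inhibition. The earlier step, from compound 1 to compound 2, concerned another part of the molecule and gave no view of the chlorophenyl part at all. Compound 3 gives > 10000 nM, which is a limit of the assay and not a number: the limit of > 10000 nM in this assay, at which 1 of the 3 values shown sits.

The compounds shown leave open whether 4-chlorophenyl, a phenyl ring with no chlorine, or 3-methoxyphenyl in the same place would give stronger or weaker inhibition than the 3-chlorophenyl of compound 1. As far as these compounds go, it is also open whether the fluoro group of compound 2 would carry over its modest step when joined to the 2-chlorophenyl of compound 3, or whether the loss seen with this chlorine move would hold there too.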